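Swapping the urea aryl group on the shorter-chain analogue

A few compounds are considered here, and "the series" means these few. Any claim that something is new, unique, unknown or untested is made for them only; others in the source may bear on it.

Measured so far: compound 1 `CCN(CC)CCCNc1nc(-c2ccc(NC(=O)Nc3ccc(Cl)cc3)cc2)nc2ccsc12` 81 nM; compound 2 `CCN(CC)CCNc1nc(-c2ccc(NC(=O)Nc3ccccc3F)cc2)nc2ccsc12` 430 nM.

In a functional assay on NCI-H460 cells (Homo sapiens) for cytotoxicity, read by MTT assay, with a stated time of 72 h (on this read-out higher numbers stand for weaker inhibition and lower numbers for stronger inhibition), compound 2 gives 430 nM, the higher of the two numbers, with compound 1 at 81 nM standing a good way lower, beyond the scatter. Compound 3 `CCN(CC)CCNc1nc(-c2ccc(NC(=O)Nc3ccc(Cl)cc3)cc2)nc2ccsc12` differs from compound 2 by 4-chlorophenyl in place of 2-fluorophenyl on an amide-type nitrogen. Since compound 1 also carries the 4-chlorophenyl group but differs from compound 3 in a second place, the expected step from compound 2 to compound 3 is a 2.9-fold lower number from compound 2 to compound 3 (0.46 log units; beyond the scatter), a moderate fall beyond the scatter, resting on compound 1 at 81 nM. Compound 3 is therefore estimated at 150 nM, likely between 50 nM and 500 nM.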

Compound 3, half-maximal inhibitory concentration: 190 nM
Compound 3: middle estimate off by 1.3-fold (0.10 log units), on the low side; the measured number falls inside the stated range.
By their numbers in this assay, from the lowest: compound 1; then compound 3; then compound 2.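

In this assay, the urea aryl group can now be read on its own: 4-chlorophenyl in place of 2-fluorophenyl on an amide-type nitrogen gives a 2.3-fold lower number from compound 2 to compound 3 (0.35 log units; beyond the scatter) with the chain held fixed. The chain can also be read on its own: with 4-chlorophenyl held fixed, diethylamino in place of (diethylamino)methyl gives a 2.3-fold higher number from compound 1 to compound 3 (0.37 log units; beyond the scatter) in the same direction as the gap first seen between the two earlier compounds. Nothing here accounts for either step.

Still open, as far as these compounds go, is how other urea aryl groups, such as 4-methoxyphenyl or unsubstituted phenyl, would compare. So is the effect of a longer chain or of a morpholine in place of the diethylamino group.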